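The source may hold more compounds than are shown below. What is called first, only, known or untested is meant among the compounds shown, and "the series" means these compounds.

Measured in an ADME assay on HEK293 cells (Homo sapiens) for cytotoxicity, read by luminescence, with a stated time of 72 h (on this read-out lower numbers stand for an effect already at smaller amounts and higher numbers for an effect only at larger amounts of compound), both values being limits:
Compound 1 `CCOC(=O)c1c(-c2cccc(F)c2)[nH]c2cc(OC)c(F)cc2c1=O`: > 22000 nM
Compound 2 `CCOC(=O)c1c(-c2cc(F)cc(OC)c2)[nH]c2cc(OC)c(F)cc2c1=O`: > 22000 nM

Compound 1 stands at > 22000 nM, which is a limit of the assay and not a number. Compound 2 gives > 22000 nM, which is also a limit. Taken together, the data so far come down to the limit of > 22000 nM in this assay, at which 2 of the 2 values shown sit. Among the measured compounds shown here, the only measured step is a step that the two limits leave unreadable from compound 1 to compound 2.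

Compound 3 `CCOC(=O)c1c(-c2cccc(-c3ccccc3Cl)c2)[nH]c2cc(OC)c(F)cc2c1=O` departs from compound 1 in one place: 2-chlorophenyl in place of fluoro on an aromatic carbon. Here 2-chlorophenyl stands in place of fluoro on an aromatic carbon, meta to a large group, and brings one more six-membered aromatic ring of carbon only. The measured step bears on this only loosely: it concerns methoxy in place of hydrogen, and its size cannot be read.

With no readable step to carry over, no clear change is expected in this assay, though a move to lower numbers remains possible. The most likely outcome is another limit. The estimated step is an at least 1.1-fold lower number from compound 1 to compound 3 (0.04 log units; that floor lies within the scatter). Compound 3 is expected at 20000 nM, with an estimated range of 7000 nM to 40000 nM.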

Compound 3, half-maximal effective concentration: > 22000 nM
Compound 3: only a limit was reported; the forecaster's own chance of this, stated with the estimate: 60%; middle value at least 1.1-fold (0.04 log units) away from the limit.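

Among the compounds shown here, compound 3 gives a limit just as compound 1 does, so the step between them cannot be read and no new step comes from this result: the limit of > 22000 nM in this assay, at which 3 of the 3 values shown sit.

The compounds shown leave open whether methoxy or 2-chlorophenyl changes anything in this assay and at which amount, if any, these compounds would show an effect.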